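The source may report more compounds than this note shows. Statements on the series, on what has been measured and on what is new or still open speak of the compounds shown alone.

Within the data shown here, in a physicochemical assay for lipophilicity, using the shake flask method, measured as octanol-water partition, at pH 7.4 (on this read-out lower numbers stand for lower lipophilicity and higher numbers for higher lipophilicity), only two compounds have been measured so far. Compound 1 (`COc1cc(F)ccc1-c1ccnc2[nH]c(C3CCN(CC(=O)N(C)C)CC3)cc12`) gives 2.9, the higher of the two numbers. Compound 2 (`COc1cc(F)ccc1-c1ccnc2[nH]c(C3CCNCC3)nc12`) gives 0, a gap well beyond the scatter. Among the measured compounds shown here, these two compounds do not differ in just one place, so no measured step isolates the effect of a single change.

Compound 3 (`COc1cc(=O)n(C)cc1-c1ccnc2[nH]c(C3CCN(CC(=O)N(C)C)CC3)cc12`) keeps the rest of compound 1 and replaces the 4-fluoro-2-methoxyphenyl group on an aromatic carbon of the core: a group of 10 heavy atoms (7 carbon, 1 nitrogen, 2 oxygen; one six-membered aromatic ring with 1 hetero atom) in place of a group of 9 heavy atoms (7 carbon, 1 oxygen, 1 fluorine; one six-membered aromatic ring of carbon only), on an aromatic carbon. The group that enters has a ring with a hetero atom, a double bond outside aromatic rings and more hydrogen-bond acceptors, and it has no fluorine. For the measured compounds named here, with no measured step as a guide, the expectation rests on this structural change alone, starting from compound 1 at 2.9. An estimated step of a number 1.50 log units lower from compound 1 to compound 3 (beyond the scatter) is expected, a fall beyond the scatter in this assay. For compound 3 the expected value is 1.4, with an estimated range from 0.8 to 2.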

Compound 3, distribution coefficient: 0.7
Compound 3: middle estimate off by 0.70 log units, on the high side; measured number below the stated range.
By their numbers in this assay, from the lowest: compound 2; then compound 3; then compound 1.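

In this assay, among these compounds, replacing the 4-fluoro-2-methoxyphenyl group with the new ring group gives a number 2.20 log units lower from compound 1 to compound 3 (beyond the scatter), the first step in this set that isolates a change in one place. It shows that the group on this aromatic carbon, opposite the ring nitrogen, can by itself move the read-out by a large amount while the rest of compound 1 stays the same. The entering group differs from the one that leaves in several ways at once, with a ring hetero atom, a double bond outside aromatic rings, more hydrogen-bond acceptors and no fluorine, and nothing measured here explains the fall or divides it among these features.

The compounds shown leave open which of these features accounts for the step; a 2-methoxyphenyl group without the fluorine, or a methoxypyridine ring without the carbonyl, would help separate them. From the compounds shown here alone, it also remains open whether the same exchange gives a step of similar size when a methyl group stands in place of the dimethylacetamide chain.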